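The source may hold more compounds than are shown below. What is called first, only, known or untested is meant among the compounds shown, and "the series" means these compounds.

Compound 1 `CCCCN(C)c1nc(C(C)(C)C)ccc1CNC(=O)C(C)c1ccc(NS(C)(=O)=O)c(F)c1` gives 1.2 nM in an assay on cells for antagonist activity at transient receptor potential cation channel subfamily V member 1 (Homo sapiens), read by FLIPR and calcium flux, with a stated time of 6 min; a higher number here means a weaker inhibitor, a lower number a stronger inhibitor.
Compound 2 `CC(C(=O)NCc1ccc(C(C)(C)C)nc1N1CCCC1)c1ccc(NS(C)(=O)=O)c(F)c1` gives 1.2 nM in this assay.
Compound 3 `CCCCN(C)c1cc(C(C)(C)C)ccc1CNC(=O)C(C)c1ccc(NS(C)(=O)=O)c(F)c1` gives 1 nM in this assay.

For the measured compounds named here, compound 1 and compound 2 share one core, and the single change between them is pyrrolidin-1-yl in place of butyl(methyl)amino on an aromatic carbon; the step it made is no change at the digits printed from compound 1 to compound 2 (within the scatter). Compound 3 carries a different core, and how it differs from compound 1 is not broken down here. Compound 4 `CC(C(=O)NCc1ccc(C(C)(C)C)cc1N1CCCC1)c1ccc(NS(C)(=O)=O)c(F)c1` has not yet been measured in this assay; it differs from compound 3 by pyrrolidin-1-yl in place of butyl(methyl)amino on an aromatic carbon. This is the same kind of change as before, not the same one: in compound 1 the place is on a six-membered aromatic ring with 1 nitrogen, next to the ring nitrogen, whereas in compound 3 it is on a six-membered aromatic ring of carbon only. Because the earlier step of no change at the digits printed from compound 1 to compound 2 (within the scatter) lay within the scatter, a step of about the same size is expected here, a 1.2-fold higher number from compound 3 to compound 4 (0.08 log units; within the scatter). Compound 4 is therefore estimated at 1.2 nM, between 0.5 nM and 3 nM.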

Compound 4, inhibition constant: 8.1 nM
Estimate against measurement, compound 4: 6.8-fold (0.83 log units) below; the measured number lies above the stated range.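

In this assay, replacing butyl(methyl)amino with pyrrolidin-1-yl did not have the same result on the two cores: the same change on two cores in this assay, no change at the digits printed (within the scatter) from compound 1 to compound 2 and an 8.1-fold higher number (0.91 log units; beyond the scatter) from compound 3 to compound 4, 8.1-fold (0.91 log units) apart, beyond the scatter of two such steps

On the core of compound 3, the change gave an 8.1-fold higher number from compound 3 to compound 4 (0.91 log units; beyond the scatter), which shows that a step seen on the core of compound 1 did not carry over to this second core. For the compounds shown here, with only one pair on each core, this does not show which difference between the cores matters, or whether other replacements would diverge in the same way.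

On these data alone, it remains open whether a smaller amine such as dimethylamino, or a larger ring such as piperidin-1-yl, would give different steps on the two cores.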